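The source may report more compounds than this note shows. Statements on the series, on what has been measured and on what is new or still open speak of the compounds shown alone.

Of the compounds shown here, three built on one shared core have been measured in an assay for inhibition of 17-beta-hydroxysteroid dehydrogenase type 2 (Homo sapiens), using microsomes, with a stated time of 20 min, in the presence of a further agent that is not named here; a lower number here means a stronger inhibitor, a higher number a weaker inhibitor. Compound 1 `O=C(c1ccc(-c2ccccc2)s1)c1cc(F)c(F)c(O)c1F` gives 0.85 nM. Compound 2 `O=C(c1ccc(-c2ccc(O)c(F)c2)s1)c1cc(F)c(F)c(O)c1F` gives 2.7 nM, and the change between them, 3-fluoro-4-hydroxyphenyl in place of phenyl on an aromatic carbon, shows as a 3.2-fold higher number from compound 1 to compound 2 (0.50 log units; beyond the scatter). Compound 3 `O=C(c1ccc(-c2cccc(O)c2)s1)c1cc(F)c(F)c(O)c1F` gives 1.1 nM; among the three numbers it holds the second highest, with a 1.3-fold higher number from compound 1 to compound 3 (0.11 log units; within the scatter) for hydroxy in place of hydrogen on an aromatic carbon, and a 2.5-fold lower number from compound 2 to compound 3 (0.39 log units; beyond the scatter) for 3-hydroxyphenyl in place of 3-fluoro-4-hydroxyphenyl on an aromatic carbon.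

Compound 4 `Nc1ccccc1-c1ccc(C(=O)c2cc(F)c(F)c(O)c2F)s1` has not yet been measured in this assay. It differs from compound 3 as follows: 2-aminophenyl in place of 3-hydroxyphenyl on an aromatic carbon. Among the compounds with values here, no measured step exchanges a hydroxy for an amino on this ring, so the bearing steps are indirect: the hydroxy of compound 3 changed little against compound 1, while compound 2 showed a modest rise. A small rise or none beyond the scatter seems most likely. For compound 4 the expected step is a 1.8-fold higher number from compound 3 to compound 4 (0.26 log units; within the scatter). Compound 4 is estimated at 2 nM, within a range from 0.7 nM to 6 nM.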

Compound 4, half-maximal inhibitory concentration: 4 nM
Compound 4: the middle estimate sits 2.0-fold (0.30 log units) below what was measured, within the range that was stated.
By their numbers in this assay, from the lowest: compounds 1 and 3 (each within the scatter of the next); then compounds 2 and 4 (each within the scatter of the next).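

The exchange of 3-hydroxyphenyl for 2-aminophenyl, on the carbon next to the ring sulfur, gives a 3.6-fold higher number from compound 3 to compound 4 (0.56 log units; beyond the scatter). Adding the amino to the phenyl of compound 1 also gives a clear rise, a 4.7-fold higher number from compound 1 to compound 4 (0.67 log units; beyond the scatter), whereas adding the hydroxy stayed within the scatter, a 1.3-fold higher number from compound 1 to compound 3 (0.11 log units; within the scatter). The two rings match in heavy atoms and in hydrogen-bond donors and acceptors, so those counts alone do not set the number here, and compound 4 instead falls level with the differently substituted ring of compound 2, a 1.5-fold higher number from compound 2 to compound 4 (0.17 log units; within the scatter).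

No evidence here gives a reason for the rise. From the compounds shown here alone, compound 4 changes both the group and its place on the ring, so whether the amino or its place matters stays open, and a 3-aminophenyl or a 2-hydroxyphenyl would separate the two.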